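The source may report more compounds than this note shows. Statements on the series, on what has been measured and on what is new or still open speak of the compounds shown alone.

Measured in a functional assay on MDA-MB-231 cells (Homo sapiens) for antiproliferative activity, read by MTT assay, with a stated time of 24 h; a lower number here means a stronger inhibitor, a higher number a weaker inhibitor:
- Compound 1 `O=C(O)CC(NS(=O)(=O)c1ccc(C(F)(F)F)cc1)c1ccccc1`: 56100 nM
- Compound 2 `O=C(O)CC(NS(=O)(=O)c1ccccc1)c1ccc(Cl)cc1Cl`: 57800 nM

Within the data shown here, these are the only two numbers available so far. Compound 2, at 57800 nM, sits level with compound 1, at 56100 nM. The gap between the two lies within the scatter of repeated measurements.

The next compound to consider is compound 3 `O=C(O)CC(NS(=O)(=O)c1ccc(C(F)(F)F)cc1)c1ccc(Cl)cc1Cl`. It keeps all of compound 2 and gains one group, trifluoromethyl in place of hydrogen on an aromatic carbon. Compound 1 carries the same group in the same place, so compound 3 unites a feature of each measured compound.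

Among the measured compounds shown here, no measured pair differs in just one place, so the size of this change in this assay has not been seen directly. The two values give no sign of a large effect, but they cannot isolate one either. The estimated step is a 1.7-fold lower number from compound 2 to compound 3 (0.22 log units; within the scatter), which is expected to be small, toward a lower number, and possibly no larger than the scatter. For compound 3 the estimated value is 35000 nM, with an expected range of 12000 nM to 90000 nM.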

Compound 3, half-maximal inhibitory concentration: 30400 nM
Beside the measured number, compound 3's estimate is 1.2-fold (0.06 log units) above it; measured number inside the range.
By their numbers in this assay, from the lowest: compounds 3, 1 and 2 (each within the scatter of the next).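

In this assay, among these compounds, trifluoromethyl in place of hydrogen on an aromatic carbon, para to a large group, can now be read directly for the first time, as a 1.9-fold lower number from compound 2 to compound 3 (0.28 log units; within the scatter). The second single change, 2,4-dichlorophenyl in place of phenyl on a saturated chain carbon bound to a saturated chain carbon and a sulfonamide nitrogen, can also be read directly, as a 1.8-fold lower number from compound 1 to compound 3 (0.27 log units; within the scatter), so neither change stands clear of the usual variation between repeated measurements, even though each step on its own is now known and no longer only inferred from two unrelated compounds. No measurement at hand offers an explanation for the size of either step.

The compounds shown leave open whether another group at that same place on the ring, such as a methoxy group, a nitrile or an amine, would give a step beyond the scatter. They also leave open whether replacing the carboxylic acid of the shared core with an ester or an amide would give such a step in this assay.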